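A few compounds are considered here, and "the series" means these few. Any claim that something is new, unique, unknown or untested is made for them only; others in the source may bear on it.

Of the compounds shown here, three built on one shared core have been measured in a functional assay on HCT-116 cells (Homo sapiens) for cytotoxicity, read by MTT assay, with a stated time of 48 h; on this read-out lower numbers stand for stronger inhibition of growth and higher numbers for weaker inhibition of growth. Compound 1 `CC(C)c1nc2cc(Cl)c(Cl)cc2[nH]1` carries an isopropyl group and a hydrogen on an aromatic nitrogen; in this assay compound 1 gives 52000 nM. Compound 2 `CCc1nc2cc(Cl)c(Cl)cc2n1C1CCCC1` carries an ethyl group and a cyclopentyl group on that nitrogen, and compound 2 gives 38000 nM. Compound 3 `CC(C)c1nc2cc(Cl)c(Cl)cc2n1C1CCCC1` combines the isopropyl and the cyclopentyl groups, and compound 3 gives 9000 nM, the lowest of the three numbers and so the strongest growth inhibitor among them. The two steps leading to it are both modest: a 5.8-fold lower number from compound 1 to compound 3 (0.76 log units; beyond the scatter) and a 4.2-fold lower number from compound 2 to compound 3 (0.63 log units; beyond the scatter).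

Compound 4 `CS(=O)(=O)c1nc2cc(Cl)c(Cl)cc2n1C1CCCC1` differs from compound 3 in one place: methylsulfonyl in place of isopropyl on an aromatic carbon. Among the measured compounds shown here, none of the measured steps swaps an alkyl group for a methylsulfonyl group, so nothing bears directly on this change. For the measured compounds named here, only a 4.2-fold lower number from compound 2 to compound 3 (0.63 log units; beyond the scatter) touches the same carbon, and it shows merely that the group there matters, with the branched alkyl giving the lowest number so far. The direction of the new change is therefore open and the uncertainty wide. On balance a weaker result is expected, about a 3.3-fold higher number from compound 3 to compound 4 (0.52 log units; beyond the scatter). Compound 4 is estimated at 30000 nM, with a range from 7000 nM to 130000 nM.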

Compound 4, concentration for 50% growth inhibition: 600 nM
Beside the measured number, compound 4's estimate is 50-fold (1.70 log units) above it, and the stated range ends above it.
By their numbers in this assay, from the lowest: compound 4; then compound 3; then compounds 2 and 1 (each within the scatter of the next).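

Until now the aromatic carbon between two ring nitrogen atoms had carried only the alkyl groups ethyl and isopropyl, and in this assay the swap between them moved the number modestly (a 4.2-fold lower number from compound 2 to compound 3 (0.63 log units; beyond the scatter)). Methylsulfonyl, which is no alkyl group and brings hydrogen-bond acceptors that isopropyl lacks, moves it much further, both against isopropyl (a 15-fold lower number from compound 3 to compound 4 (1.18 log units; beyond the scatter)) and against ethyl (a 63-fold lower number from compound 2 to compound 4 (1.80 log units; beyond the scatter)), so this position can tolerate far more than a branched alkyl group and is more sensitive than the alkyl series suggested. Nothing measured here explains why this swap lowers the number so strongly.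

The compounds shown cannot separate the contribution of the sulfur-oxygen part from that of its methyl, and ethylsulfonyl, a sulfonamide, an amine or a carboxylic acid at this carbon would help show which feature of the group counts. As far as these compounds go, it also remains open whether methylsulfonyl gives a similar drop with hydrogen in place of cyclopentyl on the aromatic nitrogen, since both compounds in this swap carry the cyclopentyl group.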